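Ring-nitrogen substituent series: outlook for compound 4

This account rests on a few compounds, and the source may have more. Where it says the series, first, only, none or still open, it means among the compounds named here.

Measured so far in a functional assay on MGC-803 cells (Homo sapiens) for antiproliferative activity, read by CCK-8 assay, with a stated time of 72 h, tested at 2 uM; a higher number here means a stronger effect of the compound at the concentration tested, a lower number a weaker effect:
- compound 1 `Nc1ccccc1NC(=O)c1ccc(CSC(=S)N2CCN(Cc3ccccn3)CC2)cc1`: 23.4%
- compound 2 `Nc1ccccc1NC(=O)c1ccc(CSC(=S)N2CCN(c3ncccn3)CC2)cc1`: 28.4%
- compound 3 `Nc1ccccc1NC(=O)c1ccc(CSC(=S)N2CCN(C3CCCCC3)CC2)cc1`: 16.9%

Compound 3 holds the lowest of the three numbers; its gap to compound 1 lies within the scatter, its gap to compound 2 beyond it. Compound 4 `Nc1ccccc1NC(=O)c1ccc(CSC(=S)N2CCN(c3cnccn3)CC2)cc1` differs from compound 3 by pyrazin-2-yl in place of cyclohexyl on an amine nitrogen in a ring. The step that bears on this is a number 11.5 percentage points lower from compound 2 to compound 3 (beyond the scatter), the reverse direction of the same kind of exchange, an aromatic ring with hetero atoms on that ring nitrogen against cyclohexyl; a number 6.5 percentage points lower from compound 1 to compound 3 (within the scatter) adds little, lying within the scatter. An upward step of similar size is therefore expected for compound 4 in this assay, namely a number 10.1 percentage points higher from compound 3 to compound 4 (beyond the scatter). Compound 4 is estimated at 27%, with a range from 18% to 36%.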

Compound 4, a percentage reported as inhibition, at one concentration (the size of the read-out at that concentration, not a potency): 27.1%
The estimate for compound 4 lay 0.1 percentage points below the measured number, within the range that was stated.
By their numbers in this assay, from the lowest: compounds 3, 1, 4 and 2 (each within the scatter of the next, the first and the last beyond it).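

In this assay a second aromatic ring with hetero atoms on this ring nitrogen repeats the gain over cyclohexyl, with a number 10.2 percentage points higher from compound 3 to compound 4 (beyond the scatter) here, so that gain does not rest on pyrimidin-2-yl alone. Pyrazin-2-yl cannot be told apart from pyrimidin-2-yl, with a number 1.3 percentage points lower from compound 2 to compound 4 (within the scatter) here, or from (pyridin-2-yl)methyl, with a number 3.7 percentage points higher from compound 1 to compound 4 (within the scatter) here. No measurement offers an explanation for these steps.

Open, going by these compounds, is whether a phenyl ring, of carbon only, would stand with the aromatic rings carrying hetero atoms or with cyclohexyl. Also open, on these data alone, is how a small group such as methyl would compare on this ring nitrogen.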